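The source may report more compounds than this note shows. Statements on the series, on what has been measured and on what is new or still open speak of the compounds shown alone.

Compound 2 `COc1cc(Cl)cc(-c2nn(-c3cccc(NC(=O)Nc4ccc(Cl)c(C(F)(F)F)c4)c3)cc2-c2ccncc2)c1` stands lowest of the three numbers in a functional assay on Hs-578T cells (Homo sapiens) for inhibition, read by sulforhodamine B assay, with a stated time of 48 h, tested at 10 uM; on this read-out higher numbers stand for a weaker effect at the one concentration tested and lower numbers for a stronger effect: compound 2 gives 14.6%. Its nearest neighbour is compound 1 `COc1cc(Cl)cc(-c2nn(-c3cccc(NC(=O)Nc4cccc(C(F)(F)F)c4)c3)cc2-c2ccncc2)c1`, which in this assay gives 23.2%; the step of a number 8.6 percentage points lower from compound 1 to compound 2 (within the scatter) lies within the scatter. Compound 3 `COc1cc(Cl)cc(-c2nn(-c3cccc(NC(=O)c4cc(C(F)(F)F)cc(C(F)(F)F)c4)c3)cc2-c2ccncc2)c1` lies furthest away and in this assay gives 81.1%. Compound 4 `COc1cc(Cl)cc(-c2nn(-c3cccc(NC(=O)c4ccc(Cl)c(Cl)c4)c3)cc2-c2ccncc2)c1` has not yet been measured. It differs from compound 2 in one place (3,4-dichlorophenyl in place of (4-chloro-3-(trifluoromethyl)phenyl)amino on a carbonyl carbon). For the measured compounds named here, the only measured step between compounds differing in one place, a number 8.6 percentage points lower from compound 1 to compound 2 (within the scatter), concerns a chloro in place of hydrogen on an aromatic carbon and does not touch the carbonyl carbon, so it bears little on this change. Like compound 4, compound 3 carries its aromatic ring on the carbonyl carbon rather than an amino group, and compound 3 gives 81.1%, far from compound 2. Compound 4 is therefore expected to move toward that region, with the estimated step of a number 50.4 percentage points higher from compound 2 to compound 4 (beyond the scatter). The estimate for compound 4 is 65%, with a range from 35% to 92%.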

Compound 4, a percentage reported as activity, at one concentration (the size of the read-out at that concentration, not a potency): 63.6%
Estimate against measurement, compound 4: 1.4 percentage points above; the measured number falls inside the stated range.
By their numbers in this assay, from the lowest: compounds 2 and 1 (each within the scatter of the next); then compound 4; then compound 3.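

On the carbonyl carbon, 3,4-dichlorophenyl in place of (4-chloro-3-(trifluoromethyl)phenyl)amino gives a number 49 percentage points higher from compound 2 to compound 4 (beyond the scatter) in this assay, and in place of (3-(trifluoromethyl)phenyl)amino it gives a number 40.4 percentage points higher from compound 1 to compound 4 (beyond the scatter). This position therefore shows a change beyond the scatter, which the chloro step on the aromatic carbon did not, and it does so from both compounds carrying an amino group there. The data given here offer no explanation for the size of these steps.

Going by these compounds, how much of each step belongs to the loss of the amino link and how much to the change of substituents on the ring stays open, as both change together. Also open, on these data alone, is how a methylene group or an ether oxygen in place of that amino link would read in this assay.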